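The source may report more compounds than this note shows. Statements on the series, on what has been measured and on what is new or still open speak of the compounds shown alone.

Going by the values given here, compound 3 `O=C(O)c1csc([C@H]2CC[C@@H]3[C@@H](CCCOc4ccccc4)[C@H](O)C[C@@H]3O2)n1` stands second highest of the three numbers so far in a functional assay on CHO cells for agonist activity at prostaglandin E2 receptor EP2 subtype (Homo sapiens), read by HTRF and cAMP accumulation, with a stated time of 30 min (a lower number here means that less compound is needed, a higher number that more compound is needed for the effect), where compound 3 gives 10 nM. Compound 2 `O=C(O)c1csc([C@H]2CC[C@@H]3[C@@H](COc4cccc(F)c4)[C@H](O)C[C@@H]3O2)n1` gives 5.4 nM, and a 1.9-fold higher number from compound 2 to compound 3 (0.27 log units; within the scatter). Compound 1 `O=C(O)c1csc([C@H]2CC[C@@H]3[C@@H](COc4ccccc4F)[C@H](O)C[C@@H]3O2)n1` gives 23 nM, and a 2.3-fold lower number from compound 1 to compound 3 (0.36 log units; beyond the scatter). Compound 4 `O=C(O)c1csc([C@H]2CC[C@@H]3[C@@H](CCOc4ccccc4)[C@H](O)C[C@@H]3O2)n1` differs from compound 3 by phenoxy in place of phenoxymethyl on a saturated chain carbon, two bonds along the chain from a saturated ring carbon, a shortening of the chain by one link. Among the compounds with values here, the steps that bear on this are the two chain-length changes already seen, a 2.3-fold lower number from compound 1 to compound 3 (0.36 log units; beyond the scatter) and a 1.9-fold higher number from compound 2 to compound 3 (0.27 log units; within the scatter), both modest or within the scatter, though each also swapped a fluorine away. Compound 4 is therefore expected to sit close to compound 3, with a 1.3-fold lower number from compound 3 to compound 4 (0.10 log units; within the scatter), and its estimated value in this assay is 8 nM, within a range from 3 nM to 25 nM.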

Compound 4, half-maximal effective concentration: 1.4 nM
Compound 4: middle estimate off by 5.7-fold (0.76 log units), on the high side, and the stated range ends above it.
By their numbers in this assay, from the lowest: compound 4; then compounds 2 and 3 (each within the scatter of the next); then compound 1.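

Going from the phenoxymethyl to the phenoxy group gives a 7.1-fold lower number from compound 3 to compound 4 (0.85 log units; beyond the scatter) in this assay, the first step that changes chain length alone, and it shows that this position responds more strongly than the earlier steps, which also removed a fluorine, had suggested. Compound 4 has the lowest number of the four, with a 3.9-fold lower number from compound 2 to compound 4 (0.59 log units; beyond the scatter) and a 16-fold lower number from compound 1 to compound 4 (1.22 log units; beyond the scatter). No measurement given here explains this. As far as these compounds go, whether a fluorine on the phenyl ring of compound 4 would help or hurt stays open, as does the effect of an amine in place of the chain oxygen.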